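This account rests on a few compounds, and the source may have more. Where it says the series, first, only, none or still open, it means among the compounds named here.

Measured so far:
compound 1 `Clc1ccc(-c2cc(-c3ccc(Cl)o3)cc(-c3ccsc3)n2)cc1`: 29.8%
compound 2 `Clc1ccc(-c2cc(-c3ccoc3)cc(-c3ccsc3)n2)cc1`: 0%

For the measured compounds named here, in an assay on isolated protein for inhibition of DNA topoisomerase 1 (Homo sapiens), tested at 100 uM (on this read-out lower numbers stand for a weaker effect and higher numbers for a stronger effect at the one concentration tested), compound 1 gives 29.8%, the higher of the two numbers so far; compound 2 sits a number 29.8 percentage points lower from compound 1 to compound 2 (beyond the scatter), a change brought by furan-3-yl in place of 5-chlorofuran-2-yl on an aromatic carbon.

Compound 3 `Cc1ccc(-c2cc(-c3ccc(Cl)o3)cc(-c3ccsc3)n2)cc1` is not yet measured. It differs from compound 1 as follows: methyl in place of chloro on an aromatic carbon, the place being an aromatic carbon of a six-membered aromatic ring of carbon only, para to a large group. Going by the values given here, no measured step touches this ring: the single step, from compound 1 to compound 2, alters the furan side of the shared core, not the phenyl side, and its size (a number 29.8 percentage points lower from compound 1 to compound 2 (beyond the scatter)) therefore says little about swapping chloro for methyl elsewhere. Among the compounds with values here, with no direct precedent, the expectation in this assay is a step of small size, more likely downward than upward, that may well stay within the scatter: a number 7.8 percentage points lower from compound 1 to compound 3 (within the scatter) is the expected shift. Compound 3 is thus estimated at 22%, with a range from 5% to 40%.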

Compound 3, a percentage reported as inhibition, at one concentration (the size of the read-out at that concentration, not a potency): 2.6%
Beside the measured number, compound 3's estimate is 19.4 percentage points above it; the whole stated range lies above it.
By their numbers in this assay, from the lowest: compounds 2 and 3 (each within the scatter of the next); then compound 1.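

In this assay, the phenyl side of the shared core turns out to be sensitive as well: methyl in place of chloro on an aromatic carbon, para to a large group, gives a number 27.2 percentage points lower from compound 1 to compound 3 (beyond the scatter). For the compounds shown here, until now, the only step beyond the scatter lay on the furan side, a number 29.8 percentage points lower from compound 1 to compound 2 (beyond the scatter), so the result adds a second place where one change removes a modest step's worth of the read-out. At this position, exchanging one heavy atom, chlorine for carbon, is enough, and of the two groups seen here, 4-chlorophenyl goes with the higher number while 4-methylphenyl gives a number within the scatter of compound 2. Going by these compounds alone, nothing measured so far bears on the reason for this step.

On these data alone, whether the step follows the loss of chloro specifically or would come with other replacements remains open, as the readings for a bromo group, a methoxy group, a fluoro group or plain hydrogen at this place are unknown. Also open, as far as these compounds go, is how the two sensitive places combine, and how any of these numbers would translate into potency, since the read-out comes from one concentration.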